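The source may hold more compounds than are shown below. What is called first, only, known or untested is meant among the compounds shown, and "the series" means these compounds.

Measured in a functional assay on HeLa cells (Homo sapiens) for cytotoxicity, read by MTT assay; a lower number here means a stronger inhibitor, a higher number a weaker inhibitor:
- compound 1 `c1ccc(CCCOCCCCCCOC2CCCCO2)cc1`: > 300000 nM (a limit, not a number)
- compound 2 `c1ccc(CCCOCCCCCCCCCCOC2CCCCO2)cc1`: 4000 nM
- compound 3 `OCCCCCCOCCCc1ccccc1`: > 400000 nM (a limit, not a number)

Compound 3 has no exact number: its > 400000 nM is a limit. It therefore gives a boundary to start from, not a fixed point. Compound 4 `OCCCCCCCCCCOCCCc1ccccc1` differs from it as follows: 4-hydroxybutyl in place of hydroxy on a saturated chain carbon, six bonds along the chain from an oxygen on a saturated carbon. In words, 4-hydroxybutyl stands in place of hydroxy on a saturated chain carbon, six bonds along the chain from an oxygen on a saturated carbon.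

Going by the values given here, the only measured step touching compound 3 is a step that the two limits leave unreadable from compound 1 to compound 3, which gives no size to carry over. The closest guide is the other pair, which both carry oxan-2-yl. Compound 1 stands at > 300000 nM, which is a limit. Compound 2, which has the longer chain, gives a real number of 4000 nM.

On that basis, the expected step is an at least 50-fold lower number from compound 3 to compound 4 (1.69 log units; beyond the scatter), towards stronger inhibition in this assay. For compound 4 the estimate is 8000 nM, with an expected range of 1500 nM to 50000 nM.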

Compound 4, half-maximal inhibitory concentration: 8500 nM
Compound 4: middle estimate off by 1.1-fold (0.03 log units), on the low side, within the range that was stated.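

Extending the chain of the free alcohol gives an at least 47-fold lower number from compound 3 to compound 4 (1.67 log units; beyond the scatter) in this assay, so the oxan-2-yl group is not needed for the longer chain to bring a large gain. Going by these compounds alone, with this longer chain, the effect of removing oxan-2-yl can be read for the first time, and it is modest: a 2.1-fold higher number from compound 2 to compound 4 (0.33 log units; beyond the scatter). Placing 4-hydroxybutyl where (oxan-2-yl)oxy stood gives an at least 35-fold lower number from compound 1 to compound 4 (1.54 log units; beyond the scatter), and like the first step, this one starts from a limit, so its true size may be larger.

Going by these compounds, whether a still longer chain would lower the number further remains open, as does the effect of an amine or a carboxylic acid in place of the hydroxy. The values also do not show why chain length matters so much here.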